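Moving the nitrile in the 4-cyanophenyl amino series

The source may hold more compounds than are shown below. What is called first, only, known or untested is meant among the compounds shown, and "the series" means these compounds.

Measured so far in a functional assay on DU-145 cells (Homo sapiens) for antiproliferative activity, read by MTT assay, with a stated time of 72 h (a lower number here means a stronger inhibitor, a higher number a weaker inhibitor), for this series:
- compound 1 `COc1cc2c(Nc3ccc(C#N)cc3)ncnc2cc1OCCCN1CCN(C)CC1`: 46500 nM
- compound 2 `COc1cc2c(Nc3ccc(C#N)cc3)ncnc2cc1OCCCN1CCN(c2ccncc2)CC1`: 22900 nM

Compound 1 stands highest of the two numbers, with compound 2 as its nearest neighbour. Among the measured compounds shown here, the only measured step is a 2.0-fold lower number from compound 1 to compound 2 (0.31 log units; beyond the scatter) with pyridin-4-yl in place of methyl on an amine nitrogen in a ring.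

Compound 3 `COc1cc2c(Nc3cccc(C#N)c3)ncnc2cc1OCCCN1CCN(C)CC1` keeps that methyl of compound 1 and changes at another place (3-cyanophenyl in place of 4-cyanophenyl on a nitrogen on an aromatic ring), with 3-cyanophenyl in place of 4-cyanophenyl on a nitrogen on an aromatic ring. For the measured compounds named here, no measured step touches this place, and the data give no direction for the change. Going by the values given here, with a 2.0-fold lower number from compound 1 to compound 2 (0.31 log units; beyond the scatter) as the only guide, modest in size and elsewhere on the structure, no step beyond the scatter is expected for compound 3 in this assay although a wide margin remains on either side. The expected step is a 1.2-fold lower number from compound 1 to compound 3 (0.07 log units; within the scatter) as a rough estimate. In this assay compound 3 is expected at 40000 nM (estimated range 15000 nM to 100000 nM).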

Compound 3, half-maximal inhibitory concentration: 12100 nM
Compound 3: middle estimate off by 3.3-fold (0.52 log units), on the high side; measured number outside the range, below it.
By their numbers in this assay, from the lowest: compounds 3 and 2 (each within the scatter of the next); then compound 1.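

In this assay, among the compounds shown here, moving the nitrile is enough to change the number: a 3.8-fold lower number from compound 1 to compound 3 (0.58 log units; beyond the scatter), a modest step with 3-cyanophenyl in place of 4-cyanophenyl on the amino nitrogen, and the first measured step at this place. For the compounds shown here, the two groups have the same atoms, joined differently, and the same counts of rings, triple bonds, donors and acceptors, so this step reflects a rearrangement alone, with the methyl and the rest of compound 1 kept, and it gives this place a direction that the earlier compounds could not. No measured information here bears on the reason for this difference between the 3-cyanophenyl and 4-cyanophenyl groups.

It remains open whether the same change would give a similar step with pyridin-4-yl on the ring amine nitrogen, as in compound 2, since the 3-cyanophenyl group is shown here only with the methyl. Also open, as far as these compounds go, is how 2-cyanophenyl would read at this place, and whether a chlorine, a methoxy group or a carboxylic acid in place of the nitrile would follow compound 3.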